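The compounds below may be only part of what the source reports. "The series", "measured", "known", "first", "only" and "open" are said of these compounds alone.

Measured so far:
compound 1 `O=C1CSc2cc(OCCCc3ccccc3)ccc2N1` — 20 nM in an assay on isolated protein for inhibition of Amine oxidase [flavin-containing] B (Homo sapiens), read by fluorescence and spectrophotometry, with a stated time of 20 min; on this read-out lower numbers stand for stronger inhibition and higher numbers for weaker inhibition
compound 2 `CCCOc1ccc2c(c1)SCC(=O)N2` — 2870 nM

Compound 2 stands at the highest of the two numbers; its nearest neighbour is compound 1, which gives 20 nM in this assay. The step from compound 2 to compound 3 `O=C1CSc2cc(OCCc3ccccc3)ccc2N1` is this: phenyl in place of methyl on a saturated chain carbon, two bonds along the chain from an oxygen on an aromatic ring. Going by the values given here, one measured step bears on it: a 140-fold higher number from compound 1 to compound 2 (2.16 log units; beyond the scatter), where removing the phenyl from the chain end of compound 1 raised the number sharply. Compound 3 puts a phenyl back, on a chain one carbon shorter than in compound 1, so in this assay a large step downward is expected, roughly of the size that step showed. Compound 3 is therefore estimated at 40 nM, with a range from 8 nM to 200 nM, which means an expected step of a 72-fold lower number from compound 2 to compound 3 (1.86 log units; beyond the scatter).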

Compound 3, half-maximal inhibitory concentration: 167 nM
Compound 3: middle estimate off by 4.2-fold (0.62 log units), on the low side, and the stated range covers the measured number.
By their numbers in this assay, from the lowest: compound 1; then compound 3; then compound 2.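

In this assay, putting a phenyl on the saturated chain carbon, two bonds along the chain from an oxygen on an aromatic ring, recovers much of the ground lost without a phenyl, with a 17-fold lower number from compound 2 to compound 3 (1.24 log units; beyond the scatter) in this series. The length of the chain carrying that ring also counts: phenyl in place of benzyl gives an 8.4-fold higher number from compound 1 to compound 3 (0.92 log units; beyond the scatter), so having the ring is not enough to match compound 1. There is no evidence here on why either change moves the number. Going by these compounds, it remains open whether a chain longer than that of compound 1 would lower the number further. On these data alone, it is also open whether an amine or a pyridine ring could stand in for the phenyl at the chain end, or how a fluorine on that phenyl would act.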